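Thiomorpholine to piperidine on the thiocarbonyl carbon

The compounds below may be only part of what the source reports. "The series", "measured", "known", "first", "only" and "open" are said of these compounds alone.

Three compounds of the series have numbers in a functional assay on A-375 cells (Homo sapiens) for cytotoxicity, read by MTT assay, with a stated time of 72 h, tested at 3 uM; a lower number here means less inhibition of growth, a higher number more inhibition of growth at the concentration tested. Compound 1 `Cc1ccnc(/C(N)=N/NC(=S)N2CCSCC2)c1` gives 67.2%, compound 2 `N/C(=N\NC(=S)N1CCSCC1)c1ccccn1` gives 80%, and compound 3 `N/C(=N\NC(=S)N1CCN(c2ccccn2)CC1)c1ccccn1` gives 73.7%. The number for compound 2 is the highest of the three; compound 3 sits within the scatter of it, while compound 1 lies beyond the scatter, the step being a number 12.8 percentage points higher from compound 1 to compound 2 (beyond the scatter) for hydrogen in place of methyl on an aromatic carbon.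

Compound 4 `N/C(=N\NC(=S)N1CCCCC1)c1ccccn1` is not yet measured. It differs from compound 2 by piperidin-1-yl in place of thiomorpholin-4-yl on a thiocarbonyl carbon. Among the compounds with values here, no measured step concerns this ring exchange; the only measured step is the methyl removal from compound 1 to compound 2, which was modest. Compound 3 carries a different ring on the same thiocarbonyl carbon, and its value and that of compound 2 lie within the scatter of one another. The expected step of a number 5 percentage points lower from compound 2 to compound 4 (within the scatter) is therefore none beyond the scatter. Compound 4 is estimated at 75%, within 60% to 88%.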

Compound 4, percent growth inhibition at one concentration: 86.5%
Beside the measured number, compound 4's estimate is 11.5 percentage points below it; low and high end bracket the measured number.
By their numbers in this assay, from the lowest: compounds 1, 3, 2 and 4 (each within the scatter of the next, the first and the last beyond it).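

Within the data shown here, this is the first step read directly at the thiocarbonyl carbon: in this assay, the exchange gives a number 6.5 percentage points higher from compound 2 to compound 4 (within the scatter). The ring sulfur of thiomorpholin-4-yl is therefore not needed to keep the read-out at this level at the single concentration tested, as the ring with nitrogen as its only hetero atom reads the same within the scatter. No accompanying measurement bears on the reason for this.

Still open, going by these compounds, is how morpholin-4-yl, with an oxygen in the ring, or an open-chain diethylamino group would read on the same thiocarbonyl carbon. Also open, on these data alone, is whether the methyl step seen with the thiomorpholin-4-yl compounds carries over to a piperidin-1-yl compound, and whether the single-concentration readings would separate compounds in a full dose-response series.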